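The compounds below may be only part of what the source reports. "The series", "measured", "known", "first", "only" and "open" are said of these compounds alone.

In a functional assay on HepG2 cells (Homo sapiens) for cytotoxicity, read by MTT assay, with a stated time of 72 h (on this read-out lower numbers stand for stronger inhibition and higher numbers for weaker inhibition), compound 1 `Cc1cc(=O)n(-c2ccc(F)cc2)nc1C(=O)Nc1ccc(Oc2ncnc3ccsc23)cc1` gives 2110 nM. Compound 2 `Cc1ccc(-n2nc(C(=O)Nc3ccc(Oc4ncnc5sccc45)cc3)c(C)cc2=O)cc1` reaches only a limit of the assay, > 40000 nM, so no number is known for it. Among the two values shown, compound 2 sits at the limit of > 40000 nM in this assay, at which 1 of the 2 values shown sits. Compound 3 `Cc1cc(=O)n(-c2ccc(F)cc2)nc1C(=O)Nc1ccc(Oc2ncnc3sccc23)cc1` differs from compound 2 by fluoro in place of methyl on an aromatic carbon. Among the compounds with values here, no measured pair covers this change, so any step is uncertain; a number, rather than a limit, for compound 3 would itself mean movement toward stronger inhibition. Compound 3 is expected to give 6000 nM, within 1500 nM to 40000 nM, as the estimated step of an at least 6.6-fold lower number from compound 2 to compound 3 (0.82 log units; beyond the scatter).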

Compound 3, half-maximal inhibitory concentration: 6460 nM
Estimate against measurement, compound 3: 1.1-fold (0.03 log units) below, and the stated range covers the measured number.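

In this assay, changing 4-methylphenyl to 4-fluorophenyl gives an at least 6.1-fold lower number from compound 2 to compound 3 (0.79 log units; beyond the scatter), so this one atom on the ring moves the read-out clearly toward stronger inhibition. The size of that step has no upper bound, since compound 2 gives only a limit: the limit of > 40000 nM in this assay, at which 1 of the 3 values shown sits. The fluoro compounds also respond to the group on the oxygen, where a group of the same atoms, differently arranged, gives a 3.1-fold higher number from compound 1 to compound 3 (0.49 log units; beyond the scatter).

Going by these compounds, whether chloro, methoxy or an amine at this position would give a lower number remains open. So does whether methyl in place of fluoro would cost as much on the core of compound 1.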